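Returning to a Secondary Amine: Compound 3 to Compound 4

The compounds below may be only part of what the source reports. "The series", "measured", "known", "first", "only" and "open" are said of these compounds alone.

Three sulfonamides here share one core and differ only in the amine at the far end of the chain. Compound 1 `O=S(=O)(NCCCCNCc1ccc(Br)cc1)c1cc(C(F)(F)F)cc(C(F)(F)F)c1` gives 2900 nM in a functional assay on ASPC1 cells (Homo sapiens) for inhibition, read by MTT assay, with a stated time of 72 h; a lower number here means a stronger inhibitor of growth, a higher number a weaker inhibitor of growth. Compound 2 `O=S(=O)(NCCCNCc1cccc(Cl)c1)c1cc(C(F)(F)F)cc(C(F)(F)F)c1` gives 5900 nM in this assay, a step of a 2.0-fold higher number from compound 1 to compound 2 (0.31 log units; beyond the scatter). Compound 3 `CN(CCCNS(=O)(=O)c1cc(C(F)(F)F)cc(C(F)(F)F)c1)Cc1ccccc1` gives 51000 nM in this assay, the highest number of the three, reached by steps of an 18-fold higher number from compound 1 to compound 3 (1.25 log units; beyond the scatter) and an 8.6-fold higher number from compound 2 to compound 3 (0.94 log units; beyond the scatter). Compound 4 `COc1ccccc1CNCCCNS(=O)(=O)c1cc(C(F)(F)F)cc(C(F)(F)F)c1` has not yet been measured; it differs from compound 3 by (2-methoxybenzyl)amino in place of benzyl(methyl)amino on a saturated chain carbon, three bonds along the chain from a sulfonamide nitrogen. Within the data shown here, two measured steps bear on this change. Compound 1 and compound 2 both carry a benzyl on a nitrogen that still bears a hydrogen, and compound 3 is the only one in which that nitrogen carries a methyl instead; because an 18-fold higher number from compound 1 to compound 3 (1.25 log units; beyond the scatter) and an 8.6-fold higher number from compound 2 to compound 3 (0.94 log units; beyond the scatter) are both large rises, compound 4, which again has a hydrogen-bearing nitrogen, is expected to give a lower number than compound 3 in this assay. Among the measured compounds shown here, the methoxy group has no counterpart among the measured compounds, so its own contribution is unknown. Compound 4 is therefore expected to give 8000 nM in this assay, between 2500 nM and 25000 nM. The expected step is a 6.4-fold lower number from compound 3 to compound 4 (0.80 log units; beyond the scatter).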

Compound 4, concentration for 50% growth inhibition: 4600 nM
For compound 4 the middle estimate is 1.7-fold (0.24 log units) above the measured one; the measured number falls inside the stated range.
By their numbers in this assay, from the lowest: compounds 1, 4 and 2 (each within the scatter of the next, the first and the last beyond it); then compound 3.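

In this assay the change to (2-methoxybenzyl)amino, which puts a hydrogen on the amine nitrogen where compound 3 has a methyl, brings an 11-fold lower number from compound 3 to compound 4 (1.04 log units; beyond the scatter), so a large fall at this place now stands beside the large rises that led to compound 3. The other two steps lie within the scatter, a 1.3-fold lower number from compound 2 to compound 4 (0.11 log units; within the scatter) and a 1.6-fold higher number from compound 1 to compound 4 (0.20 log units; within the scatter), although the second also spans a longer chain; among the listed compounds, only compound 3, the one with a methyl on that nitrogen, stands beyond the scatter from all the others, and a 2-methoxyphenyl here reads the same as a 3-chlorophenyl within that scatter. No measurement is available that would explain any of these steps.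

The step from compound 3 to compound 4 changes the methyl and the methoxy group together, so the share of each remains unseparated. On these data alone, it also remains open how this position would respond to an ethyl group on the amine nitrogen, or to a hydroxyl group or a nitrile on the benzyl ring in place of the methoxy group.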